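A Pyridine Ring Replaces Thiophene in a Cytotoxicity Series

A few compounds are considered here, and "the series" means these few. Any claim that something is new, unique, unknown or untested is made for them only; others in the source may bear on it.

Of the compounds shown here, three have been measured in a toxicity assay on Vero C1008 cells (Chlorocebus sabaeus) for cytotoxicity, read by neutral red uptake, with a stated time of 5 days; on this read-out lower numbers stand for higher toxicity in this test and higher numbers for lower toxicity in this test. Compound 1 `C[C@H](NC(=O)C(c1cccnc1)N(C(=O)c1ccco1)c1ccc([Si](C)(C)C)cc1)c1ccccc1` gives 19400 nM. Compound 2 `C[C@H](NC(=O)C(c1cccnc1)N(C(=O)c1ccco1)c1ccc(-c2ccco2)cc1)c1ccccc1` gives 56400 nM, and compound 3 `C[C@H](NC(=O)C(c1cccnc1)N(C(=O)c1ccco1)c1ccc(-c2cccs2)cc1)c1ccccc1` gives 89600 nM. Compound 3 stands highest of the three numbers in this assay, but its gap to compound 2 is within the scatter, so the two cannot be ordered; only its gap to compound 1 is beyond the scatter, as a 4.6-fold higher number from compound 1 to compound 3 (0.66 log units; beyond the scatter) shows.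

Compound 4 `C[C@H](NC(=O)C(c1cccnc1)N(C(=O)c1ccco1)c1ccc(-c2ccccn2)cc1)c1ccccc1` has not yet been measured. It differs from compound 3 in one place: pyridin-2-yl in place of thiophen-2-yl on an aromatic carbon. Within the data shown here, the steps that bear on this change are a 1.6-fold higher number from compound 2 to compound 3 (0.20 log units; within the scatter), which exchanged one five-membered aromatic ring for another on the same carbon, and a 2.9-fold higher number from compound 1 to compound 2 (0.46 log units; beyond the scatter) together with a 4.6-fold higher number from compound 1 to compound 3 (0.66 log units; beyond the scatter), where an aromatic ring entered in place of a group with no ring. The first exchange stayed within the scatter; the other two were modest rises. Since pyridin-2-yl is again an aromatic ring with one hetero atom, no step beyond the scatter is expected in this assay, and the expected step is a 1.3-fold lower number from compound 3 to compound 4 (0.11 log units; within the scatter). Compound 4 is therefore estimated at 70000 nM, with an expected range from 30000 nM to 160000 nM.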

Compound 4, half-maximal cytotoxic concentration: 236000 nM
The estimate for compound 4 lay 3.4-fold (0.53 log units) below the measured number; measured number outside the range, above it.
By their numbers in this assay, from the lowest: compound 1; then compounds 2 and 3 (each within the scatter of the next); then compound 4.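

In this assay, the aromatic carbon para to a large group proved more responsive than the exchange between the two five-membered rings had shown: with pyridin-2-yl, the first six-membered aromatic ring here, the series gave a 2.6-fold higher number from compound 3 to compound 4 (0.42 log units; beyond the scatter) and a 4.2-fold higher number from compound 2 to compound 4 (0.62 log units; beyond the scatter), both beyond the scatter, whereas thiophen-2-yl and furan-2-yl could not be ordered. Among these compounds, measured against the silicon-bearing group with no ring, the new ring gave a 12-fold higher number from compound 1 to compound 4 (1.09 log units; beyond the scatter), the only step into compound 4 that counts as large, so compound 4 now holds the highest number of the set, which in this test stands for lower toxicity. Nothing available accounts for this rise in the number, so the change can be described but not explained.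

Compound 4 differs from compound 3 in both ring size and hetero atom, so the compounds shown cannot say which of the two goes with the higher number. A plain phenyl ring at this place would separate the two, and a pyridine ring carrying an amine would show how far the number responds to further change on the new ring.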